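This account rests on a few compounds, and the source may have more. Where it says the series, first, only, none or still open, it means among the compounds named here.

Of the compounds shown here, three from one series have so far been measured in a functional assay on MIA PaCa-2 cells (Homo sapiens) for inhibition, read by MTT assay, with a stated time of 3 days; on this read-out lower numbers stand for stronger inhibition and higher numbers for weaker inhibition. Compound 1 `CCOC(=O)[C@@H]1CCCN(S(=N)(=O)c2ccc(S(=O)(=O)N(CC)CC)cc2)C1` gives 4700 nM. Compound 2 `CCN(CC)S(=O)(=O)c1ccc(S(=O)(=O)N2CCC[C@@H](C(=O)N(C)C(C)C)C2)cc1` gives 1400 nM. Compound 3 `CCN(CC)S(=O)(=O)c1ccc(S(=O)(=O)N2CCC[C@@H](C(=O)N3CCN(c4nc(C(F)(F)F)no4)CC3)C2)cc1` gives 60 nM. On these numbers compound 2 stands second highest of the three: compound 1 sits at a higher number and compound 3 at a far lower one, and both gaps lie beyond the scatter of repeated measurements. The account now turns to compound 4 `CCN(CC)S(=O)(=O)c1ccc(S(=O)(=O)N2CCC[C@@H](C(=O)NC)C2)cc1`, not yet measured in this assay. It differs from compound 2 in one place: hydrogen in place of isopropyl on an amide-type nitrogen. Going by the values given here, no pair of measured compounds differs in exactly this way, so the size of the step cannot be read directly from the numbers at hand. What the measured compounds show is that compound 3, carrying the most extended group on the amide carbonyl, gives the lowest number at 60 nM, while compound 2 with a smaller group gives 1400 nM. Compound 4 carries the smallest group of all at that position, and its number is expected to move upward by a 2.3-fold higher number from compound 2 to compound 4 (0.36 log units; beyond the scatter), a step a little beyond the scatter. The estimate for compound 4 is 3200 nM, within a range from 1200 nM to 9000 nM.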

Compound 4, half-maximal inhibitory concentration: 2000 nM
For compound 4 the middle estimate is 1.6-fold (0.20 log units) above the measured one; the measured number falls inside the stated range.
By their numbers in this assay, from the lowest: compound 3; then compounds 2 and 4 (each within the scatter of the next); then compound 1.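

In this assay the change from isopropyl to hydrogen on the amide-type nitrogen amounts to a 1.4-fold higher number from compound 2 to compound 4 (0.15 log units; within the scatter) and so leaves no difference that this read-out can resolve. Going by these compounds alone, for this pair, the isopropyl group with its three carbons is not needed to hold the number at this level, and the methylcarbamoyl group serves as well as the isopropyl(methyl)carbamoyl group, something the earlier compounds could not show, since no measured pair differed at this nitrogen alone. Nothing among the data at hand offers an explanation for this result.

The compounds shown leave open whether an ethyl group, a longer chain or a chain ending in an amine or a carboxylic acid on this nitrogen would stay level with compound 2 and compound 4 or move away from them. Within the data shown here, also open is what follows when the remaining methyl on that nitrogen gives way to hydrogen, and whether a change at this nitrogen would matter as little with a larger group on the carbonyl, such as the one in compound 3.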